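Nitro in Place of Cyano: Expected Step at the Amine Ring

The compounds below may be only part of what the source reports. "The series", "measured", "known", "first", "only" and "open" are said of these compounds alone.

Compound 1 `CC1(C)CC(NC(=S)Nc2ccc(C#N)cc2)c2cc(F)ccc2O1` — 5000 nM
Compound 2 `CC1(C)CC(NC(=S)Nc2ccc(C#N)cc2)c2cc(Cl)ccc2O1` — 7000 nM

Of the compounds shown here, two have been measured in a functional assay on B16-F10 cells (Mus musculus) for inhibition, read by MTT assay, with a stated time of 72 h; on this read-out lower numbers stand for stronger inhibition and higher numbers for weaker inhibition. Compound 1 gives 5000 nM, the lowest of the two numbers, and compound 2 gives 7000 nM. Among the measured compounds shown here, the one measured step, a 1.4-fold higher number from compound 1 to compound 2 (0.15 log units; within the scatter), concerns the halogen on the shared core and lies within the scatter, so the two values cannot be ordered.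

Compound 3 `CC1(C)CC(NC(=S)Nc2ccc([N+](=O)[O-])cc2)c2cc(F)ccc2O1` has not yet been measured. It differs from compound 1 as follows: nitro in place of cyano on an aromatic carbon. The measured step does not touch the cyano group, so nothing measured bears directly on this change. For the measured compounds named here, with no relevant step to draw on, the expectation is a step of no change at the digits printed from compound 1 to compound 3 (within the scatter), that is, nothing beyond the scatter, in either direction. Compound 3 is therefore estimated at 5000 nM, with a range from 1500 nM to 16000 nM.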

Compound 3, half-maximal inhibitory concentration: 4000 nM
The estimate for compound 3 lay 1.3-fold (0.10 log units) above the measured number, and the stated range covers the measured number.
By their numbers in this assay, from the lowest: compounds 3, 1 and 2 (each within the scatter of the next).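

At this position, on an aromatic carbon para to a large group, nitro in place of cyano gives a 1.3-fold lower number from compound 1 to compound 3 (0.10 log units; within the scatter) in this assay. Among the compounds shown here, this is the first measured change at the group itself, and with fluoro on the shared core the two compounds cannot be ordered, although nitrile and nitro differ in their atoms and hydrogen-bond acceptors. Nothing measured here explains why the exchange leaves the number within the scatter.

On these data alone, whether nitro and cyano also match with chloro on the core stays open, for the nitro group appears here only with fluoro. Also open is whether an amine, a carboxylic acid or a methoxy group at this position would move the number beyond the scatter, a size that no step shown so far reaches.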